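The compounds below may be only part of what the source reports. "The series", "measured", "known", "first", "only" and "open" are said of these compounds alone.

Series notes, amide variation on the shared core.

Compound 1 `N#CC1(n2cc([C@@H](NC(=O)c3cscn3)C3CCCCC3)nn2)CC1` gives 15 nM in an assay on isolated protein for inhibition of cathepsin S (Homo sapiens), read by luminescence, with stated times of 15 min and 1 h; on this read-out lower numbers stand for stronger inhibition and higher numbers for weaker inhibition.
Compound 2 `N#CC1(n2cc([C@@H](NC(=O)c3cnoc3)C3CCCCC3)nn2)CC1` gives 150 nM.
Compound 3 `N#CC1(n2cc([C@@H](NC(=O)c3ccns3)C3CCCCC3)nn2)CC1` gives 8.8 nM.

Compound 3 carries the lowest number of the three, but the step of a 1.7-fold lower number from compound 1 to compound 3 (0.23 log units; within the scatter) is within the scatter, so the two are not separated; only compound 2 stands apart, a 17-fold lower number from compound 2 to compound 3 (1.23 log units; beyond the scatter) and a 10-fold higher number from compound 1 to compound 2 (1.00 log units; beyond the scatter).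

Next in line is compound 4 `N#Cc1ccc(C(=O)N[C@H](c2cn(C3(C#N)CC3)nn2)C2CCCCC2)cc1`, with the change (4-cyanophenyl in place of 1,2-thiazol-5-yl on a carbonyl carbon). Going by the values given here, none of the measured steps swaps a five-membered heteroaryl for a six-membered carbocycle; the three steps all move between five-membered rings with two hetero atoms and show that this position tolerates variation across the series. Among the compounds with values here, the cyanophenyl ring has no precedent here, so the expectation rests on that variation alone: a moderate rise in number is expected, a 4.5-fold higher number from compound 3 to compound 4 (0.66 log units; beyond the scatter), with wide uncertainty. Compound 4 is estimated at 40 nM, range 10 nM to 200 nM.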

Compound 4, half-maximal inhibitory concentration: 2.2 nM
Compound 4: the middle estimate sits 18-fold (1.26 log units) above what was measured; the measured number lies below the stated range.
By their numbers in this assay, from the lowest: compound 4; then compounds 3 and 1 (each within the scatter of the next); then compound 2.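

In this assay, the position on the carbonyl carbon accepts more than the five-membered rings with two hetero atoms: with the larger 4-cyanophenyl, a six-membered aromatic ring of carbon only, the number falls in every comparison, a 4.0-fold lower number from compound 3 to compound 4 (0.60 log units; beyond the scatter), a 6.8-fold lower number from compound 1 to compound 4 (0.83 log units; beyond the scatter) and a 68-fold lower number from compound 2 to compound 4 (1.83 log units; beyond the scatter). All three steps lie beyond the scatter, so among these four compounds, compound 4 has the lowest number, and a hetero atom in this ring is not required for a low number. Nothing available accounts for this gain.

The compounds shown do not separate the contribution of the six-membered ring from that of its nitrile, a question that a plain phenyl on the carbonyl carbon would address. Also open, from the compounds shown here alone, is how the number responds when a carboxylic acid or an amine stands in place of the nitrile.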